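Methyl for methoxy across two cores of one series

A few compounds are considered here, and "the series" means these few. Any claim that something is new, unique, unknown or untested is made for them only; others in the source may bear on it.

Compound 2 `COc1ccc(-n2nc(C(C)=O)s/c2=N\c2nc(-c3c(C)n(C)n(-c4ccccc4)c3=O)cs2)cc1` gives 26500 nM in a functional assay on A549 cells (Homo sapiens) for cytotoxicity, read by sulforhodamine B assay, with a stated time of 72 h; on this read-out lower numbers stand for stronger inhibition and higher numbers for weaker inhibition. Compound 1 `CC(=O)c1nn(-c2ccc(C)cc2)/c(=N/c2nc(-c3c(C)n(C)n(-c4ccccc4)c3=O)cs2)s1` differs from it by methyl in place of methoxy on an aromatic carbon and in this assay compound 1 gives 20700 nM, a step of a 1.3-fold lower number from compound 2 to compound 1 (0.11 log units; within the scatter). Compound 3 `COc1ccc(/C=C2\S/C(=N\c3nc(-c4c(C)n(C)n(-c5ccccc5)c4=O)cs3)N(c3ccccc3)C2=O)cc1` rests on a different core; the difference between the two cores is not broken down here. In this assay compound 3 gives 9100 nM, the lowest number of the three measured. Compound 4 `Cc1ccc(/C=C2\S/C(=N\c3nc(-c4c(C)n(C)n(-c5ccccc5)c4=O)cs3)N(c3ccccc3)C2=O)cc1` differs from compound 3 by methyl in place of methoxy on an aromatic carbon, the same change, at the same place on the ring, as that between compound 2 and compound 1. Because that earlier change gave a 1.3-fold lower number from compound 2 to compound 1 (0.11 log units; within the scatter), a step of about the same small size is expected here: a 1.2-fold lower number from compound 3 to compound 4 (0.07 log units; within the scatter). Compound 4 is therefore estimated at 7800 nM in this assay, likely between 3500 nM and 17000 nM.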

Compound 4, half-maximal inhibitory concentration: > 100000 nM
Compound 4: a limit, no number; the forecaster's own chance of this, stated with the estimate: 5%; middle value at least 12-fold (1.10 log units) away from the limit.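

Methyl in place of methoxy does not carry from one core to the other in this assay, where on the core of compound 3 the step is an at least 10-fold higher number from compound 3 to compound 4 (1.04 log units; beyond the scatter), far from the earlier result: the same change on two cores in this assay, a 1.3-fold lower number (0.11 log units; within the scatter) from compound 2 to compound 1 and an at least 10-fold higher number (1.04 log units; beyond the scatter) from compound 3 to compound 4, at least 14-fold (1.14 log units) apart, beyond the scatter of two such steps.
From the compounds shown here alone, compound 4 gives > 100000 nM, which is a limit of the assay and not a number, so the full size of this step stays unknown: the limit of > 100000 nM in this assay, at which 1 of the 4 values shown sits.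
The two pairs show that the step on one core did not predict the step on the other, but they do not show why the two cores part, and the difference between the cores is not broken down.

Open, going by these compounds, is how other groups on the same aromatic carbon, such as a chlorine atom or an amine, would behave on either core. Two pairs also cannot say which core's behaviour is the usual one in this series.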